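The source may hold more compounds than are shown below. What is called first, only, known or untested is meant among the compounds shown, and "the series" means these compounds.

Measured compounds in a functional assay on A549 cells (Homo sapiens) for antiproliferative activity, read by sulforhodamine B assay, with a stated time of 72 h; a higher number here means a weaker inhibitor of growth, a lower number a stronger inhibitor of growth:
- compound 1 `Cc1cc(=O)oc2cc(Sc3cccc(Cl)n3)ccc12` gives 2110 nM
- compound 2 `Cc1cc(=O)oc2cc(SC3CCOC3=O)ccc12` gives > 36100 nM
- compound 3 `Cc1cc(=O)oc2cc(SCc3cccc(C(F)(F)F)c3)ccc12` gives > 28500 nM

Compound 3 stands at the edge of what this assay reports: its value of > 28500 nM is a limit and not a number. Compound 2 likewise sits at a limit, > 36100 nM, in this assay. Of the three measured compounds only compound 1 returns a true number, 2110 nM; compound 1 carries its thioether directly on a chloropyridine, whereas compound 2 and compound 3 carry it on a lactone and on a benzyl group. Among the compounds with values here, two of the three values are limits, as the limit of > 28500 nM in this assay, at which 1 of the 3 values shown sits, and the limit of > 36100 nM in this assay, at which 1 of the 3 values shown sits, record, so no step between measured compounds can be sized.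

Compound 4 `Cc1cc(=O)oc2cc(SCc3cccc(C#N)c3)ccc12` is the next member to be measured. It differs from compound 3 by cyano in place of trifluoromethyl on an aromatic carbon. The thioether linkage, the benzyl spacer and the shared core remain unchanged.

Within the data shown here, with compound 3 at a limit and no measured step to lean on, the step that the limit leaves unreadable from compound 3 to compound 4 is expected to be small, with no direction beyond the scatter claimed. Compound 4 is therefore estimated at 30000 nM in this assay, within a range of 8000 nM to 100000 nM, and it is expected that a limit rather than a number may again be reported.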

Compound 4, concentration for 50% growth inhibition: > 32500 nM
Compound 4 gave a limit, no number (the forecaster's own chance of this, stated with the estimate: 60%); middle value at least 1.0-fold (0.03 log units) away from the limit.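

In this assay compound 4 gives > 32500 nM, a limit and not a number. Within the data shown here, compound 3 gives > 28500 nM, also a limit, so no step from compound 3 to compound 4 can be read. The compounds shown leave open whether cyano in place of trifluoromethyl on an aromatic carbon alters growth inhibition at all.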